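Swapping 3-carboxypropyl for amino on a shared core

The source may report more compounds than this note shows. Statements on the series, on what has been measured and on what is new or still open speak of the compounds shown alone.

Compound 1 `O=C(Cn1cc(CO)nn1)NCc1ccccc1`: 490 uM
Compound 2 `CCC(O)Cc1cn(CC(=O)NCc2ccccc2)nn1`: 630 uM
Compound 3 `O=C(O)CCCCc1cn(CC(=O)NCc2ccccc2)nn1`: 1080 uM

In an ADME assay on cells (spleen, Mus musculus, strain C57BL/6) for inhibition, read by flow cytometry and propidium iodide staining, with a stated time of 24 h, at 37 degrees C (a lower number here means that less compound is needed, a higher number that more compound is needed for the effect), compound 3 gives 1080 uM. Within the data shown here, only one step sets it clearly apart: a 2.2-fold higher number from compound 1 to compound 3 (0.34 log units; beyond the scatter). The other step reaching it is smaller, a 1.7-fold higher number from compound 2 to compound 3 (0.23 log units; within the scatter), and the remaining pair also stays close, with a 1.3-fold higher number from compound 1 to compound 2 (0.11 log units; within the scatter).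

The next compound is compound 4 `NCc1cn(CC(=O)NCc2ccccc2)nn1`, which changes the same place: amino in place of 3-carboxypropyl on a saturated chain carbon bound to an aromatic carbon. Amino takes the place of 3-carboxypropyl, on a saturated chain carbon bound to an aromatic carbon. Among the measured compounds shown here, no measured step makes this exact swap, so the guide is indirect. The closest relative is compound 1, which carries hydroxy on that carbon and gives 490 uM. A modest move to a lower number is therefore expected, possibly one that stays within the scatter. The expected step is a 1.8-fold lower number from compound 3 to compound 4 (0.26 log units; within the scatter). The estimate for compound 4 is 600 uM, with an expected range of 280 uM to 1200 uM.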

Compound 4, concentration for half-maximal effect: > 2000 uM
Compound 4: only a limit was reported; the forecaster's own chance of this, stated with the estimate: 5%; middle value at least 3.3-fold (0.52 log units) away from the limit.
By their numbers in this assay, from the lowest: compounds 1, 2 and 3 (each within the scatter of the next, the first and the last beyond it). At a limit, above all of these: compound 4.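

Compound 4 has no exact number, only a limit: the limit of > 2000 uM in this assay, at which 1 of the 4 values shown sits.

Even so, the limit is enough to set amino apart at this saturated chain carbon bound to an aromatic carbon, with an at least 4.0-fold higher number from compound 1 to compound 4 (0.61 log units; beyond the scatter) and an at least 3.1-fold higher number from compound 2 to compound 4 (0.50 log units; beyond the scatter). Compounds 1, 2 and 3 had shown only small differences among hydroxy, 1-hydroxypropyl and 3-carboxypropyl, so amino in place of hydroxy gives the first step from compound 1 that is at least modest, while the change from compound 3 reads only as an at least 1.8-fold higher number from compound 3 to compound 4 (0.26 log units; that floor lies within the scatter).

That floor leaves open how far compound 4 truly lies from compound 3, since its real value could sit anywhere past the limit. Also open, from the compounds shown here alone, is whether a longer chain ending in an amine, or a plain amide at this place, would read like amino or like 3-carboxypropyl.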